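From 4-chlorobenzyl to 4-methylphenyl: working notes on compound 4

The source may report more compounds than this note shows. Statements on the series, on what has been measured and on what is new or still open speak of the compounds shown alone.

Three compounds of the series have numbers in a functional assay on SH-SY5Y cells (Homo sapiens) for inhibition, read by sulforhodamine B assay (on this read-out lower numbers stand for stronger inhibition and higher numbers for weaker inhibition), so far. Compound 1 `COC(=O)CC/C(C)=C/Cc1c(OC)c(C)c2c(c1OCC#CCN1CCN(c3ccc(O)cc3)CC1)C(=O)OC2` gives 46100 nM there, compound 2 `COC(=O)CC/C(C)=C/Cc1c(OC)c(C)c2c(c1OCC#CCN1CCN(Cc3ccc(Cl)cc3)CC1)C(=O)OC2` gives 31200 nM there and compound 3 `COC(=O)CC/C(C)=C/Cc1c(OC)c(C)c2c(c1OCC#CCN1CCN(C(c3ccccc3)c3ccc(Cl)cc3)CC1)C(=O)OC2` gives 9900 nM there. Compound 2 stands second highest of the three numbers, within the scatter of compound 1 and clearly apart from compound 3.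

Among the measured compounds shown here, compound 4 `COC(=O)CC/C(C)=C/Cc1c(OC)c(C)c2c(c1OCC#CCN1CCN(c3ccc(C)cc3)CC1)C(=O)OC2` differs from compound 2 by 4-methylphenyl in place of 4-chlorobenzyl on an amine nitrogen in a ring as its only change: 4-methylphenyl in place of 4-chlorobenzyl on an amine nitrogen in a ring.

For the measured compounds named here, two measured steps bear on this. The closer one is a 1.5-fold lower number from compound 1 to compound 2 (0.17 log units; within the scatter) for 4-chlorobenzyl in place of 4-hydroxyphenyl on that same nitrogen, an exchange of similar kind that stays within the scatter. The other is a 3.2-fold lower number from compound 2 to compound 3 (0.50 log units; beyond the scatter) for an added phenyl on a saturated chain carbon, a modest step beyond the scatter, and compound 4 has no such added phenyl. Going by the values given here, no compound with 4-methylphenyl has been measured yet.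

On this basis no step beyond the scatter is expected in this assay here. The expected change is a 1.0-fold lower number from compound 2 to compound 4 (0.02 log units; within the scatter) at most in size, with either direction open. For compound 4 the estimated value is 30000 nM with an expected range of 13000 nM to 65000 nM as the working bracket.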

Compound 4, half-maximal inhibitory concentration: 37700 nM
Compound 4: middle estimate off by 1.3-fold (0.10 log units), on the low side, within the range that was stated.
By their numbers in this assay, from the lowest: compound 3; then compounds 2, 4 and 1 (each within the scatter of the next).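

The exchange of 4-chlorobenzyl for 4-methylphenyl on the amine nitrogen in the ring gives a 1.2-fold higher number from compound 2 to compound 4 (0.08 log units; within the scatter) in this assay, so a benzyl group and a directly attached phenyl group at this nitrogen are not told apart by this read-out in this pair. Among the compounds shown here, with the phenyl group kept on the nitrogen, methyl in place of hydroxy on an aromatic carbon gives a 1.2-fold lower number from compound 1 to compound 4 (0.09 log units; within the scatter), which adds the first comparison of two groups at that ring carbon and shows no separation between them either. No independent measurement accompanies these numbers that could account for this result.

The step from compound 2 changes the chlorine and the benzyl link together, so the pair cannot assign any contribution to either one, and a 4-chlorophenyl group on the same nitrogen would be needed to separate them. As far as these compounds go, it also remains open whether this insensitivity holds for an amine or a carboxylic acid at that aromatic carbon, or for a longer chain between the ring nitrogen and the aromatic ring.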